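This account rests on a few compounds, and the source may have more. Where it says the series, first, only, none or still open, it means among the compounds named here.

Notes on the series. Compound 3 `N#Cc1cc(N2C[C@H]3CCNC[C@H]32)cnc1Br` gives 172 nM in a functional assay on HEK293 cells for agonist activity at Neuronal acetylcholine receptor; alpha4/beta2 (Homo sapiens), read by FLIPR; a higher number here means that more compound is needed for the effect, a lower number that less compound is needed. Among the three measured compounds this is the second highest number. Compound 1 `N#Cc1cncc(N2C[C@H]3CCNC[C@H]32)c1`, which carries hydrogen in place of the bromo group, gives 1930 nM. The mirror image of compound 3 is compound 2 `N#Cc1cc(N2C[C@@H]3CCNC[C@@H]32)cnc1Br`, which gives 109 nM. The step of an 11-fold lower number from compound 1 to compound 3 (1.05 log units; beyond the scatter) is large. The step of a 1.6-fold higher number from compound 2 to compound 3 (0.20 log units; within the scatter) stays within the scatter, which is read against (the fact that compounds 2 and 3 differ only in the configuration as drawn).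

Compound 4 `NC(=O)c1cc(N2C[C@H]3CCNC[C@H]32)cnc1Br` differs from compound 3 by carbamoyl in place of cyano on an aromatic carbon. Within the data shown here, neither measured step bears on this change: one concerns the bromo group and the other the configuration, and no measured pair in the set exchanges the nitrile for another group. The expectation therefore rests on the change itself, without a measured analogue to lean on. The bromo-bearing core is kept, so the gain seen in an 11-fold lower number from compound 1 to compound 3 (1.05 log units; beyond the scatter) is expected to carry over, while the replacement of the nitrile by the carbamoyl group is expected to give back part of it, in the direction of a higher number, by a step of the size a 2.9-fold higher number from compound 3 to compound 4 (0.46 log units; beyond the scatter). Compound 4 is thus estimated at 500 nM, with a range from 150 nM to 2000 nM.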

Compound 4, half-maximal effective concentration: 340 nM
Compound 4: middle estimate off by 1.5-fold (0.17 log units), on the high side; the range from low to high includes it.
By their numbers in this assay, from the lowest: compounds 2, 3 and 4 (each within the scatter of the next, the first and the last beyond it); then compound 1.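

At the aromatic carbon ortho to a bromo group, the exchange of cyano for carbamoyl gives a 2.0-fold higher number from compound 3 to compound 4 (0.30 log units; within the scatter) in this assay, so the two compounds cannot be told apart in this read-out. Among these compounds, the earlier compounds varied only the bromo group and the configuration, and this is the first measured pair to change the nitrile position: here a group with a double bond outside the ring and a hydrogen-bond donor replaces one with a triple bond and no donor, with no step beyond the scatter. Nothing available bears on why the two groups read alike.

This single pair leaves open whether the same exchange reads the same way on the mirror-image form, as in compound 2, or without the bromo group, as in compound 1. It also leaves open how a carboxylic acid, a methyl ester, an aminomethyl group or a longer chain at this position would read, and so how far the position accepts change beyond carbamoyl.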